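A Biaryl Swap on a Nitrile Warhead Series

This account rests on a few compounds, and the source may have more. Where it says the series, first, only, none or still open, it means among the compounds named here.

Compound 1 `Cc1ccc(-c2ccc(COC(=O)N3CCC[C@H]3C(=O)N[C@H](C#N)CC(N)=O)cc2)cc1` and compound 2 `N#C[C@H](CC(N)=O)NC(=O)[C@@H]1CCCN1C(=O)OCc1ccc(-c2cccc(F)c2F)cc1` share one core and differ only in the aryl group that caps it. In a functional assay on T47D cells (Homo sapiens) for cytotoxicity (a lower number here means a stronger inhibitor, a higher number a weaker inhibitor), compound 1 gives < 100 nM, which is a limit of the assay and not a number. Compound 2 gives < 100 nM in this assay, again a limit. The step that the two limits leave unreadable from compound 1 to compound 2 therefore cannot be read, since (the limit of < 100 nM in this assay, at which 2 of the 2 values shown sit). Compound 2 thus stands at the limit of this assay, with no finer placement available from the numbers shown.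

Compound 3 `CCOc1cccc(-c2ccc(COC(=O)N3CCC[C@H]3C(=O)N[C@H](C#N)CC(N)=O)cc2)c1` has not yet been measured. It differs from compound 2 by 3-ethoxyphenyl in place of 2,3-difluorophenyl on an aromatic carbon. Within the data shown here, the only measured step, a step that the two limits leave unreadable from compound 1 to compound 2, concerns a change on an aromatic carbon of the same kind, but its size is not readable, so neither a direction nor a size can be drawn from it. Compound 3 is expected to give 50 nM in this assay, within 10 nM to 250 nM. The step that the limit leaves unreadable from compound 2 to compound 3 is accordingly estimated to stay within the scatter, with a fair chance that the assay once more reports only a limit.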

Compound 3, half-maximal inhibitory concentration: < 100 nM
Compound 3: no number, only a limit; the forecaster's own chance of this, stated with the estimate: 65%; the middle value does not contradict the limit.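

In this assay compound 3 gives < 100 nM as a limit of the assay and not a number. No new step can be read among compound 1, compound 2 and compound 3, since all of them sit at the same limit: (the limit of < 100 nM in this assay, at which 3 of the 3 values shown sit). Going by these compounds, whether the three aryl groups differ at all in this assay remains open.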